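This account rests on a few compounds, and the source may have more. Where it says the series, first, only, none or still open, it means among the compounds named here.

Working notes on the series in a functional assay on HepG2 cells (Homo sapiens) for cytotoxicity, read by MTT assay, with a stated time of 24 h; a higher number here means a weaker inhibitor, a lower number a stronger inhibitor: compound 1 `O=C1/C(=C/c2ccncc2)CN(S(=O)(=O)c2ccccc2)C/C1=C\c1ccccc1F` gives 5800 nM, compound 2 `O=C1/C(=C/c2ccncc2)CN(S(=O)(=O)c2ccc([N+](=O)[O-])cc2)C/C1=C\c1ccccc1F` gives 11300 nM, and compound 3 `O=C1/C(=C/c2ccncc2)CN(S(=O)(=O)c2ccc(Cl)cc2)C/C1=C\c1ccccc1F` gives 5300 nM. Compound 3 cannot be separated from compound 1, with a 1.1-fold lower number from compound 1 to compound 3 (0.04 log units; within the scatter). It stands apart from compound 2 only modestly, with a 2.1-fold lower number from compound 2 to compound 3 (0.33 log units; beyond the scatter). Compound 4 `CC(=O)Nc1ccc(S(=O)(=O)N2C/C(=C\c3ccncc3)C(=O)/C(=C/c3ccccc3F)C2)cc1` carries acetamido in place of chloro on an aromatic carbon, para to a large group: acetamido in place of chloro on an aromatic carbon. For the measured compounds named here, no measured compound carries acetamido, so the evidence is indirect. The closest guide is the swap of hydrogen for nitro, with a 1.9-fold higher number from compound 1 to compound 2 (0.29 log units; within the scatter), together with the two steps above. All three are small, so no step beyond the scatter is expected in this assay, and no firm direction. The expected step is a 1.3-fold higher number from compound 3 to compound 4 (0.12 log units; within the scatter). Compound 4 is estimated at 7000 nM, with an expected range of 3500 nM to 14000 nM.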

Compound 4, half-maximal inhibitory concentration: 11700 nM
Beside the measured number, compound 4's estimate is 1.7-fold (0.22 log units) below it; low and high end bracket the measured number.
By their numbers in this assay, from the lowest: compounds 3, 1, 2 and 4 (each within the scatter of the next, the first and the last beyond it).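

In this assay, acetamido at this position on the sulfonyl-bound aromatic ring separates from chloro, though only modestly (a 2.2-fold higher number from compound 3 to compound 4 (0.34 log units; beyond the scatter)). It cannot be separated from nitro (a 1.0-fold higher number from compound 2 to compound 4 (0.02 log units; within the scatter)) or from hydrogen (a 2.0-fold higher number from compound 1 to compound 4 (0.30 log units; within the scatter)). Acetamido and nitro thus read alike here and both stand apart from chloro, while hydrogen stays within the scatter of all three.

On these data alone, whether an amine or a carboxylic acid at this position would read with chloro or with acetamido and nitro remains open. Nothing at hand explains these steps.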